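The compounds below may be only part of what the source reports. "The series", "measured", "known", "first", "only" and "open" are said of these compounds alone.

Measured so far in a functional assay on microsomes from aorta for inhibition of Thromboxane-A synthase (Homo sapiens), in the presence of a further agent that is not named here; on this read-out lower numbers stand for stronger inhibition and higher numbers for weaker inhibition:
- compound 1, `Cn1cc(/C=C/C(=O)O)cc1Cn1ccnc1`, gives 4600 nM
- compound 2, `C/C(=C/c1ccc(Cc2cccnc2)n1C(C)C)C(=O)O`, gives 2100 nM
- compound 3, `C/C(=C\c1ccc(Cn2ccnc2)[nH]1)C(=O)O`, gives 9100 nM

Compound 2 gives the lowest number of the three; its nearest neighbour is compound 1 and its furthest is compound 3, and both gaps lie beyond the scatter, so compound 2 is the strongest inhibitor among the measured compounds in this assay.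

The next compound, compound 4, `C/C(=C/c1ccc(Cc2cccnc2)n1CC(C)(C)C)C(=O)O`, differs from compound 2 in one place: neopentyl in place of isopropyl on an aromatic nitrogen. For the measured compounds named here, no measured pair shows what such a change does in this assay, so the expectation rests on compound 2 alone. A step of no more than the scatter, in either direction, is expected from compound 2 to compound 4, a 1.1-fold lower number from compound 2 to compound 4 (0.02 log units; within the scatter). Compound 4 is therefore estimated at 2000 nM, within a range from 700 nM to 6000 nM.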

Compound 4, half-maximal inhibitory concentration: 78000 nM
The estimate for compound 4 lay 39-fold (1.59 log units) below the measured number; the measured number lies above the stated range.
By their numbers in this assay, from the lowest: compound 2; then compounds 1 and 3 (each within the scatter of the next); then compound 4.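

On the aromatic nitrogen, replacing isopropyl (3 heavy atoms) with neopentyl (5 heavy atoms) gives a 37-fold higher number from compound 2 to compound 4 (1.57 log units; beyond the scatter) in this assay. This position therefore does not treat all carbon-only groups alike: a change that brings in no hydrogen-bond donors or acceptors and no net charge can still greatly weaken inhibition. Going by these compounds, whether an ethyl group, a cyclopropyl ring or a chain ending in an amine on this nitrogen would keep the number of compound 2 remains open. Nothing shown here explains the size of this step.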